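Swapping pyridin-3-yl for pyridin-4-yl on a shared core

The source may hold more compounds than are shown below. What is called first, only, known or untested is meant among the compounds shown, and "the series" means these compounds.

- Compound 1 `Oc1cccc(-c2cc(-c3ccccc3)nc(-c3ccsc3)c2)c1`: 11700 nM
- Compound 2 `Oc1cccc(-c2cc(-c3ccccc3)nc(-c3cccnc3)c2)c1`: 18900 nM

Both numbers come from a functional assay on DU-145 cells (Homo sapiens) for cytotoxicity, read by ELISA, with a stated time of 2 days; on this read-out higher numbers stand for weaker inhibition and lower numbers for stronger inhibition. Among the measured compounds shown here, with only two compounds measured, compound 2 at 18900 nM has a single neighbour, compound 1 at 11700 nM, and the two values lie within the usual scatter of each other.

The next compound, compound 3 `Oc1cccc(-c2cc(-c3ccccc3)nc(-c3ccncc3)c2)c1`, differs from compound 2 in one place: pyridin-4-yl stands in place of pyridin-3-yl on an aromatic carbon, (pyridin-4-yl in place of pyridin-3-yl on an aromatic carbon). The two have the same atoms, joined differently.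

For the measured compounds named here, only one measured step bears on this place: a 1.6-fold higher number from compound 1 to compound 2 (0.21 log units; within the scatter), seen on replacing thiophen-3-yl with pyridin-3-yl. That exchange of one ring for another stayed within the scatter. Going by the values given here, no measured compound carries pyridin-4-yl, so the data give no direction for the new step, and no change beyond the scatter is expected in this assay.

The estimate therefore amounts to an expected 1.2-fold lower number from compound 2 to compound 3 (0.07 log units; within the scatter). Compound 3 is expected at 16000 nM, with an estimated range from 7000 nM to 35000 nM.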

Compound 3, half-maximal inhibitory concentration: 18100 nM
For compound 3 the middle estimate is 1.1-fold (0.05 log units) below the measured one; low and high end bracket the measured number.
By their numbers in this assay, from the lowest: compounds 1, 3 and 2 (each within the scatter of the next).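

In this assay, moving the point of attachment on the pyridine ring, with pyridin-4-yl in place of pyridin-3-yl on the aromatic carbon next to the ring nitrogen of the shared core, gives a 1.0-fold lower number from compound 2 to compound 3 (0.02 log units; within the scatter) and so makes no difference that repeated measurements could separate from ordinary variation. Exchanging thiophen-3-yl for pyridin-4-yl gives a 1.5-fold higher number from compound 1 to compound 3 (0.19 log units; within the scatter) and completes the picture: thiophen-3-yl, pyridin-3-yl and pyridin-4-yl all lie within the scatter of one another at this place, so this read-out does not distinguish among these three aromatic rings, whereas the earlier pair could speak for only two of them. Nothing available here offers a reason for this flat result.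

These compounds leave open whether a group of a different kind at this place, such as a morpholine ring, a primary amine or a carboxylic acid, would move the number beyond the scatter. They also leave open how much the 3-hydroxyphenyl and phenyl groups contribute, for instance whether a methoxy group in place of the hydroxyl would change the value.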